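Bromo for tert-butyl on compound 1

A few compounds are considered here, and "the series" means these few. Any claim that something is new, unique, unknown or untested is made for them only; others in the source may bear on it.

In a functional assay on HCT-116 cells (Homo sapiens) for antiproliferative activity, read by MTT assay, with a stated time of 72 h (a lower number here means a stronger inhibitor, a higher number a weaker inhibitor), compound 1 (`COc1ccc(/C=C2/CN(C)/C(=N/c3ccc(C(C)(C)C)cc3)S2)cc1`) gives 25900 nM. Among the measured compounds shown here, the only other compound measured so far, compound 2 (`FC(F)(F)c1cc(/N=C2/NC/C(=C/c3ccccc3)S2)cc(C(F)(F)F)c1`), gives 16100 nM, which places the two within the usual scatter of each other. Compound 3 (`COc1ccc(/C=C2/CN(C)/C(=N/c3ccc(Br)cc3)S2)cc1`) keeps the core of compound 1 but carries bromo in place of tert-butyl on an aromatic carbon. For the measured compounds named here, no measured pair shows what this swap does, so no step beyond the scatter is expected. The estimated step is a 1.3-fold lower number from compound 1 to compound 3 (0.11 log units; within the scatter). Compound 3 is expected at 20000 nM, with an estimated range of 8000 nM to 50000 nM.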

Compound 3, half-maximal inhibitory concentration: 8900 nM
Compound 3: middle estimate off by 2.2-fold (0.35 log units), on the high side; measured number inside the range.
By their numbers in this assay, from the lowest: compounds 3, 2 and 1 (each within the scatter of the next, the first and the last beyond it).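

Swapping the four-carbon tert-butyl for the single-atom bromo gives a 2.9-fold lower number from compound 1 to compound 3 (0.46 log units; beyond the scatter). Among the compounds shown here, this is the first step that can be read for a single change, and it shows that the group on this aromatic carbon matters for antiproliferative activity, even though the two groups count the same for hydrogen-bond donors and acceptors. No available evidence explains the step. Still open, on these data alone, is how other groups at this carbon, such as chloro, an amine or a carboxylic acid, would compare with bromo, and whether the same swap would give a similar step on a different core.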